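Plasma half-life notes on two ester pairs

The source may report more compounds than this note shows. Statements on the series, on what has been measured and on what is new or still open speak of the compounds shown alone.

Compound 1 `CC1=C(CC(=O)OCCOc2ccc3oc(=O)ccc3c2)c2cc(F)ccc2/C1=C\c1ccc([S+](C)[O-])cc1` and compound 3 `CC1=C(CC(=O)OCCOc2ccc3ccc(=O)oc3c2)c2cc(F)ccc2/C1=C\c1ccc([S+](C)[O-])cc1` share one core; compound 2 `CC(C(=O)OCCOc1ccc2oc(=O)ccc2c1)c1cccc(C(=O)c2ccccc2)c1` and compound 4 `CC(C(=O)OCCOc1ccc2ccc(=O)oc2c1)c1cccc(C(=O)c2ccccc2)c1` share another. The difference between the two cores is not broken down here. In an ADME assay on a cell-free system (plasma, Rattus norvegicus, strain Sprague-Dawley) for metabolic stability, read by LC-MS (a higher number here means that the compound lasts longer, a lower number that the compound disappears faster), compound 1 gives 0.0917 h. Compound 3 gives 0.277 h. Compound 2 gives 0.0783 h; its value and that of compound 1 lie within the scatter of each other, while compound 3 stands beyond both.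

The change from compound 1 to compound 3 is a group of 11 heavy atoms (9 carbon, 2 oxygen; one six-membered aromatic ring of carbon only, one six-membered aromatic ring with 1 hetero atom) in place of a group of 11 heavy atoms (9 carbon, 2 oxygen; one six-membered aromatic ring of carbon only, one six-membered aromatic ring with 1 hetero atom), on an oxygen on a saturated carbon, and it gave a 3.0-fold higher number from compound 1 to compound 3 (0.48 log units; beyond the scatter). The change from compound 2 to compound 4 is a group of 11 heavy atoms (9 carbon, 2 oxygen; one six-membered aromatic ring of carbon only, one six-membered aromatic ring with 1 hetero atom) in place of a group of 11 heavy atoms (9 carbon, 2 oxygen; one six-membered aromatic ring of carbon only, one six-membered aromatic ring with 1 hetero atom), on an oxygen on a saturated carbon; the place of the change reads the same in both pairs, so this is the same change, seen once so far. Among the compounds with values here, for compound 4 a step of a 2.9-fold higher number from compound 2 to compound 4 (0.47 log units; beyond the scatter) is expected, resting only on the single step of a 3.0-fold higher number from compound 1 to compound 3 (0.48 log units; beyond the scatter) that the same change made on the other core. Compound 4 is therefore estimated at 0.23 h in this assay, with the likely range from 0.1 h to 0.5 h.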

Compound 4, half-life: 0.035 h
Estimate against measurement, compound 4: 6.6-fold (0.82 log units) above; measured number outside the range, below it.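

In this assay, the swap of these two groups on the oxygen does not carry over from one core to the other: on the second core it gives a 2.2-fold lower number from compound 2 to compound 4 (0.35 log units; beyond the scatter). Set beside the earlier step, the direction reverses, so a step measured on one core gave no usable forecast for the other in this series: the same change on two cores in this assay, a 3.0-fold higher number (0.48 log units; beyond the scatter) from compound 1 to compound 3 and a 2.2-fold lower number (0.35 log units; beyond the scatter) from compound 2 to compound 4, 6.8-fold (0.83 log units) apart, beyond the scatter of two such steps. Within the data shown here, this does not show what sets the direction, and with a single pair on each core it gives no general rule; it shows only that in these four compounds the outcome of the swap depends on the core.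

On these data alone, the difference between the two cores is not broken down here, so it remains open which part of them goes with the reversal. Also open, as far as these compounds go, is whether the same reversal would appear with a longer chain in place of the saturated chain carrying the oxygen, or with an amide in place of the ester.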